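An ethoxy group in place of methyl on compound 2

The compounds below may be only part of what the source reports. "The series", "measured", "known", "first", "only" and "open" are said of these compounds alone.

Of the compounds shown here, two of a shared core have been measured in a functional assay on MCF7 cells (Homo sapiens), tested at 5 uM; a lower number here means a stronger effect, a higher number a weaker effect of the compound at the concentration tested. Compound 1 `C=CCOc1c(C)c(C)c2c(c1C)CCC(C)(COc1ccc(/C=C3\SC(=O)NC3=O)cc1OC)O2` gives 5% in this assay, and compound 2 `C=CCOc1c(C)c(C)c2c(c1C)CCC(C)(COc1ccc(/C=C3\SC(=O)NC3=O)cc1C)O2` gives 24%. For the measured compounds named here, compound 2 therefore stands at the higher of the two numbers, the weaker effect, and its only neighbour is compound 1, the single step between them being a number 19 percentage points higher from compound 1 to compound 2 (beyond the scatter).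

Compound 3 `C=CCOc1c(C)c(C)c2c(c1C)CCC(C)(COc1ccc(/C=C3\SC(=O)NC3=O)cc1OCC)O2` has not yet been measured. It differs from compound 2 in one place: ethoxy in place of methyl on an aromatic carbon. Going by the values given here, only one measured step bears on this change, the exchange of methoxy for methyl at the same aromatic carbon, a number 19 percentage points higher from compound 1 to compound 2 (beyond the scatter). The ethoxy group brings back the 1 hydrogen-bond acceptor that methyl lacks, so compound 3 is expected to land lower than compound 2, with an estimated step of a number 14 percentage points lower from compound 2 to compound 3 (beyond the scatter), because compound 1 with its methoxy gave 5%. Among the compounds with values here, with one step as the only guide the range stays wide. Compound 3 is estimated at 10% in this assay, between 0% and 28%.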

Compound 3, a percentage reported as activity, at one concentration (the size of the read-out at that concentration, not a potency): 87%
Compound 3: the middle estimate sits 77 percentage points below what was measured, and the stated range ends below it.
By their numbers in this assay, from the lowest: compound 1; then compound 2; then compound 3.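

In this assay, the aromatic carbon ortho to a large group turns out to be far more sensitive than the exchange of methoxy for methyl alone had shown: ethoxy in place of methyl gives a number 63 percentage points higher from compound 2 to compound 3 (beyond the scatter), a large step where a number 19 percentage points higher from compound 1 to compound 2 (beyond the scatter) was modest. The two groups that carry an oxygen on this carbon also lie at opposite ends of the three, since methyl in place of hydrogen on a saturated chain carbon bound to an oxygen on an aromatic ring, the small extension that turns methoxy into ethoxy, gives a number 82 percentage points higher from compound 1 to compound 3 (beyond the scatter), so the presence of that oxygen does not by itself set the read-out here. Nothing at hand explains why so small an extension weakens the effect so much.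

The compounds shown leave open whether the effect keeps weakening as the chain grows, which a longer chain such as propoxy on this oxygen would test, or whether ethoxy is a special case. They also leave open how an amine or a hydroxyl on this carbon would compare with methoxy, methyl and ethoxy.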